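The source may report more compounds than this note shows. Statements on the series, on what has been measured and on what is new or still open speak of the compounds shown alone.

Working notes on the series. Compound 1 `O=C(O)Cc1sc(C(c2ccc(F)cc2)c2ccc(F)cc2)nc1-c1ccnc(F)c1` is the reference point; in an in vitro assay on HEK385-7 cells for displacement of a labelled ligand from prostaglandin D2 receptor 2 (Homo sapiens) (on this read-out higher numbers stand for weaker inhibition and lower numbers for stronger inhibition), compound 1 gives 0.48 nM. Going by the values given here, compound 2 `COc1ccc(OC)c(-c2nc(C(c3ccccc3)c3ccccc3)sc2CC(=O)O)c1` is the only other compound with a result. In this assay compound 2 returns only a limit of the assay, > 105 nM, so no number is known for it. Among the compounds with values here, of the two values shown, that of compound 1 is the only one that is a number; the other entry is the limit of > 105 nM in this assay, at which 1 of the 2 values shown sits, a limit rather than a measurement. Within the data shown here, no pair of measured compounds differing in a single place is available, so the effect of a single change cannot be read from the data.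

Compound 3 `O=C(O)Cc1sc(C(c2ccc(F)cc2)c2ccc(F)cc2)nc1-c1cc(F)nc(F)c1` is not yet measured. It differs from compound 1 by fluoro in place of hydrogen on an aromatic carbon, which read one bond further out is 2-fluoropyridin-4-yl going to 2,6-difluoropyridin-4-yl. A second fluoro on the same six-membered ring is a small addition; the expectation is that the step of a 1.3-fold higher number from compound 1 to compound 3 (0.10 log units; within the scatter) stays within the usual scatter, with no direction favoured. Compound 3 is therefore expected at 0.6 nM, with a range of 0.25 nM to 1.5 nM.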

Compound 3, half-maximal inhibitory concentration: 5.4 nM
For compound 3 the middle estimate is 9.0-fold (0.95 log units) below the measured one, outside the stated range (above it).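

In this assay, this position on the ring is not a neutral place for a substituent: an 11-fold higher number from compound 1 to compound 3 (1.05 log units; beyond the scatter) follows when 2-fluoropyridin-4-yl becomes 2,6-difluoropyridin-4-yl, a change of a single heavy atom. Going by these compounds alone, this is the first single change that can be read, and it shows that a fluoro on the aromatic carbon next to the ring nitrogen, meta to the existing fluoro, moves the number beyond the scatter, towards weaker inhibition. Nothing in the data shown accounts for the size of this step.

Going by these compounds, with a single step at one position, it remains open whether the loss is specific to fluoro or would also follow from another group on the same carbon, such as chloro, methyl, methoxy or an amine. Also open is what the fluoro already present in compound 1 contributes, since the plain pyridin-4-yl analogue and analogues carrying chloro or methyl in its place are not among the compounds shown.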